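The source may hold more compounds than are shown below. What is called first, only, known or untested is meant among the compounds shown, and "the series" means these compounds.

Three compounds share one core and were tested in a functional assay on NCI/ADR-RES cells (Homo sapiens) for cytotoxicity, read by sulforhodamine B assay, with a stated time of 48 h, tested at 0.01 uM; on this read-out lower numbers stand for a stronger effect and higher numbers for a weaker effect at the one concentration tested. Compound 1 `COc1cc(-c2cc(/C=C/C(=O)c3ccc(Cl)c(Cl)c3)[nH]n2)cc(OC)c1OC` gives 100% in this assay. Compound 2 `COc1ccc(C(=O)/C=C/c2cc(-c3cc(OC)c(OC)c(OC)c3)n[nH]2)cc1OC` gives 99%, and compound 3 `COc1ccc(C(=O)/C=C/c2cc(-c3cc(OC)c(OC)c(OC)c3)n[nH]2)cc1` gives 102%. Compound 3 stands close to both others: the step of a number 2 percentage points higher from compound 1 to compound 3 (within the scatter) and the step of a number 3 percentage points higher from compound 2 to compound 3 (within the scatter) lie within the scatter, as does the step of a number 1 percentage points lower from compound 1 to compound 2 (within the scatter). Compound 4 `COc1cc(-c2cc(/C=C/C(=O)c3ccc(F)c(F)c3)[nH]n2)cc(OC)c1OC` differs from compound 3 by 3,4-difluorophenyl in place of 4-methoxyphenyl on a carbonyl carbon. The steps bearing on this change are the swaps of aryl groups on the carbonyl carbon, a number 2 percentage points higher from compound 1 to compound 3 (within the scatter) and a number 1 percentage points lower from compound 1 to compound 2 (within the scatter), both within the scatter, so no step beyond the scatter is expected here. The expected step is a number 2 percentage points lower from compound 3 to compound 4 (within the scatter). Compound 4 is therefore estimated at 100%, between 90% and 110%.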

Compound 4, a percentage reported as activity, at one concentration (the size of the read-out at that concentration, not a potency): 100%
Compound 4: the middle estimate sits on the measured number at the digits printed; the measured number falls inside the stated range.
By their numbers in this assay, from the lowest: compounds 2, 1, 4 and 3 (each within the scatter of the next).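

In this assay, 3,4-difluorophenyl on the carbonyl carbon reads alike with each earlier aryl group: a number 2 percentage points lower from compound 3 to compound 4 (within the scatter), a number 1 percentage points higher from compound 2 to compound 4 (within the scatter) and no change at the digits printed from compound 1 to compound 4 (within the scatter). Among these four compounds, then, fluorine, chlorine and methoxy-bearing aryl groups at this place do not separate at the one concentration tested. Nothing available explains this. As far as these compounds go, whether the aryl groups would separate at another concentration stays open. So does the outcome of placing an amine or a carboxylic acid on the carbonyl-bound aryl ring.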